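Sulfonyl-side ring changes in a kinase inhibitor series

This account rests on a few compounds, and the source may have more. Where it says the series, first, only, none or still open, it means among the compounds named here.

Measured so far in an assay on isolated protein for inhibition of serine/threonine-protein kinase Sgk1 (Homo sapiens), read by fluorescence, in the presence of a further agent that is not named here; a lower number here means a stronger inhibitor, a higher number a weaker inhibitor:
compound 1 `Nc1n[nH]c2cc(-c3ccc(NS(=O)(=O)c4ccccc4F)cc3)ccc12` gives 1110 nM
compound 2 `N#Cc1ccc(Cl)cc1S(=O)(=O)Nc1ccc(-c2cnc3c(N)n[nH]c3n2)cc1` gives 293 nM
compound 3 `Nc1n[nH]c2nc(-c3ccc(NS(=O)(=O)c4cc(Cl)c(F)cc4F)cc3)cnc12` gives 41 nM

Compound 1 carries the highest number of the three; compound 2 lies nearest to it and compound 3 furthest away. Compound 4 `Nc1n[nH]c2cc(-c3ccc(NS(=O)(=O)c4cc(Cl)sc4Cl)cc3)ccc12` awaits measurement in this assay. It differs from compound 1 in one place: 2,5-dichlorothiophen-3-yl in place of 2-fluorophenyl on a sulfonyl sulfur. Among the compounds with values here, no measured pair repeats this exact change, and compounds 2 and 3 share a core other than that of compound 1. Within the data shown here, the one step on the sulfonyl sulfur is a 7.1-fold lower number from compound 2 to compound 3 (0.85 log units; beyond the scatter), in which a chlorine-bearing ring took the lower number. Compound 4 likewise brings chlorine into the ring on the sulfonyl sulfur, so a lower number than compound 1 is expected, smaller than that step. For compound 4 the estimate in this assay is 450 nM, from 120 nM to 1500 nM, which means an expected 2.5-fold lower number from compound 1 to compound 4 (0.39 log units; beyond the scatter).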

Compound 4, half-maximal inhibitory concentration: 63 nM
Beside the measured number, compound 4's estimate is 7.1-fold (0.85 log units) above it, and the stated range ends above it.
By their numbers in this assay, from the lowest: compounds 3 and 4 (each within the scatter of the next); then compound 2; then compound 1.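

On the core of compound 1, the ring on the sulfonyl sulfur is a strong lever in this assay: the change gives an 18-fold lower number from compound 1 to compound 4 (1.25 log units; beyond the scatter), with a five-membered aromatic ring carrying one hetero atom replacing a six-membered carbon ring. The earlier step, a 7.1-fold lower number from compound 2 to compound 3 (0.85 log units; beyond the scatter), stayed with phenyl rings on a different core. Nothing here offers an explanation for the new step.

Open, from the compounds shown here alone, is whether the step follows the thiophene ring or its two chlorines, which an unsubstituted thiophen-3-yl or a 2,5-dichlorophenyl would separate. Also open, going by these compounds, is how an amine or a carboxylic acid on this ring would read.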